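A few compounds are considered here, and "the series" means these few. Any claim that something is new, unique, unknown or untested is made for them only; others in the source may bear on it.

Measured in a functional assay on MDA-MB-436 cells (Homo sapiens) for antiproliferative activity, read by MTT assay, with a stated time of 24 h; a higher number here means a weaker inhibitor, a lower number a stronger inhibitor:
compound 1 `O=C(O)CC(NC(=O)c1ccc(C(F)(F)F)cc1)c1ccccc1F`: 66800 nM
compound 2 `COc1ccc(C(=O)NC(CC(=O)O)c2ccc(Cl)cc2Cl)cc1`: > 100000 nM (a limit)

Compound 2 stands at the limit of > 100000 nM in this assay, at which 1 of the 2 values shown sits, so only a limit is known for it. Compound 3 `O=C(O)CC(NC(=O)c1ccc(C(F)(F)F)cc1)c1ccc(Cl)cc1Cl` keeps the rest of compound 2 and has trifluoromethyl in place of methoxy on an aromatic carbon, para to a large group: trifluoromethyl in place of methoxy on an aromatic carbon. Among the compounds with values here, no measured pair isolates this change. Compound 3 shares the trifluoromethyl with compound 1, which gives 66800 nM. On that single comparison, a modest shift towards stronger inhibition in this assay is expected, with the estimated step of an at least 1.4-fold lower number from compound 2 to compound 3 (0.15 log units; that floor lies within the scatter). The size of this step stays loose, as its starting point is only a limit. For compound 3 the expected value is 70000 nM, with an estimated range of 30000 nM to 130000 nM. A result reported only as a limit remains possible.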

Compound 3, half-maximal inhibitory concentration: 44100 nM
Estimate against measurement, compound 3: 1.6-fold (0.20 log units) above; low and high end bracket the measured number.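

In this assay, within the data shown here, trifluoromethyl in place of methoxy on an aromatic carbon, para to a large group, now has a measured step, an at least 2.2-fold lower number from compound 2 to compound 3 (0.35 log units; beyond the scatter), which no earlier pair could give. This step is only a floor, because one end of it is a limit: the limit of > 100000 nM in this assay, at which 1 of the 3 values shown sits. With trifluoromethyl held constant, 2,4-dichlorophenyl in place of 2-fluorophenyl gives a 1.5-fold lower number from compound 1 to compound 3 (0.18 log units; within the scatter), so these two groups on the chain carbon are not separated in this assay.

From the compounds shown here alone, the true size of the methoxy to trifluoromethyl step remains open, as does whether it would be the same with 2-fluorophenyl on the chain carbon. Also open is how a nitrile or an amine would read at the same aromatic carbon, since the compounds shown carry only methoxy and trifluoromethyl there.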